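The source may hold more compounds than are shown below. What is called first, only, known or untested is meant among the compounds shown, and "the series" means these compounds.

Compound 3 `CN1CCN(CCCC(=O)c2ccc(-c3ccc(N4C[C@H](Cn5ccnn5)OC4=O)cc3F)cn2)CC1` reads > 400000 nM in a physicochemical assay for solubility, read by nephelometry (on this read-out higher numbers stand for higher solubility and lower numbers for lower solubility), which is a limit of the assay and not a number. Compound 1 `CN1CCN(CCCC(O)c2ccc(-c3ccc(N4C[C@H](Cn5ccnn5)OC4=O)cc3F)cn2)CC1` reads > 400000 nM, which is also a limit. Compound 2 `O=C1O[C@@H](Cn2ccnn2)CN1c1ccc(-c2ccc(CO)nc2)c(F)c1` gives an actual number, 100000 nM.

Compound 4 `COCc1ccc(-c2ccc(N3C[C@H](Cn4ccnn4)OC3=O)cc2F)cn1` has methoxymethyl in place of the (3-(4-methylpiperazin-1-yl)propyl)carbonyl of compound 3, on an aromatic carbon of a six-membered aromatic ring with 1 nitrogen: methoxymethyl in place of (3-(4-methylpiperazin-1-yl)propyl)carbonyl on an aromatic carbon.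

Within the data shown here, two measured steps bear on this change. Putting hydrogen in place of the 3-(4-methylpiperazin-1-yl)propyl gives an at least 4.0-fold lower number from compound 1 to compound 2 (0.60 log units; beyond the scatter). Putting the (3-(4-methylpiperazin-1-yl)propyl)carbonyl in place of hydroxymethyl gives an at least 4.0-fold higher number from compound 2 to compound 3 (0.60 log units; beyond the scatter). In both steps the compound without the chain has the lower number, and compound 4 lacks that chain too. Only these three compounds support the pattern, and none goes against it.

A fall beyond the scatter is therefore expected in this assay, estimated as an at least 5.7-fold lower number from compound 3 to compound 4 (0.75 log units; beyond the scatter). Compound 4 is estimated at 70000 nM, with an expected range from 20000 nM to 220000 nM.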

Compound 4, solubility: 100000 nM
Compound 4: the middle estimate sits 1.4-fold (0.15 log units) below what was measured; low and high end bracket the measured number.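

In this assay, putting methyl in place of the hydrogen on the oxygen gives no change at the digits printed from compound 2 to compound 4 (within the scatter), so on this aromatic carbon, next to the ring nitrogen, the two small groups read alike. Compound 4 also sits well under both compounds that carry a chain, with an at least 4.0-fold lower number from compound 3 to compound 4 (0.60 log units; beyond the scatter) and an at least 4.0-fold lower number from compound 1 to compound 4 (0.60 log units; beyond the scatter), so the fall seen for compound 2 recurs in a second compound without the chain, and here that compound lacks the hydroxyl hydrogen. These sizes are only minimum sizes because each step starts from a limit of the assay and not a number: the limit of > 400000 nM in this assay, at which 2 of the 4 values shown sit.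

The compounds shown leave open how much of the chain goes with the higher reading. A shorter chain ending in a dimethylamine, or a carboxylic acid at this position, could help to separate the roles of its parts.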